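Working notes: aryl ketone exchange from compound 1 to compound 3

The compounds below may be only part of what the source reports. "The series", "measured", "known", "first", "only" and "open" are said of these compounds alone.

Measured compounds:
compound 1, `COc1cc(-c2cc(/C=C/C(=O)c3ccc(N)cc3)[nH]n2)cc(OC)c1OC`, 56%
compound 2, `COc1ccc(-c2cc(/C=C/C(=O)c3ccc(OC)c(OC)c3)[nH]n2)cc1`, 51%

In a functional assay on HCT-116 cells (Homo sapiens) for cytotoxicity, read by sulforhodamine B assay, with a stated time of 48 h, tested at 1 uM (a lower number here means a stronger effect, a higher number a weaker effect of the compound at the concentration tested), compound 1 gives 56%, the higher of the two numbers, while compound 2 gives 51%; the gap lies within the scatter, so the two show no order. Compound 3, `COc1cc(-c2cc(/C=C/C(=O)c3ccc(Cl)c(Cl)c3)[nH]n2)cc(OC)c1OC`, is not yet measured. It differs from compound 1 as follows: 3,4-dichlorophenyl in place of 4-aminophenyl on a carbonyl carbon. No step between measured compounds covers this exchange, so nothing shown fixes its size or direction; a step from compound 1 to compound 3 within the scatter is expected, a number 4 percentage points lower from compound 1 to compound 3 (within the scatter). For compound 3 the expected value is 52%, estimated between 28% and 78%.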

Compound 3, a percentage reported as activity, at one concentration (the size of the read-out at that concentration, not a potency): 80%
Estimate against measurement, compound 3: 28 percentage points below; the whole stated range lies below it.
By their numbers in this assay, from the lowest: compounds 2 and 1 (each within the scatter of the next); then compound 3.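

Going by these compounds alone, the aryl group on the carbonyl carbon is not a neutral choice in this assay: 3,4-dichlorophenyl in place of 4-aminophenyl gives a number 24 percentage points higher from compound 1 to compound 3 (beyond the scatter), the first step beyond the scatter and a weaker effect at the concentration tested. Nothing shown explains this step.

From the compounds shown here alone, the exchange removes the amine and brings in both chlorines in one step, so their separate contributions remain open. Plain phenyl, 4-chlorophenyl or 4-hydroxyphenyl on the same carbonyl carbon would help to separate them.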